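This account rests on a few compounds, and the source may have more. Where it says the series, first, only, none or still open, it means among the compounds named here.

Compound 3 `COc1ccc(/C=C/C(=O)Nc2cc(C(=O)c3cc(OC)c(OC)c(OC)c3)cc(OC)c2OC)cc1N` belongs to a small set of three amides built on a shared core, all tested in a functional assay on B16 cells (Mus musculus) for cytotoxicity, read by MTT assay, with a stated time of 72 h; a lower number here means a stronger inhibitor, a higher number a weaker inhibitor. In this assay compound 3 gives 12700 nM. Its two relatives are compound 1 `COc1ccc(/C=C/C(=O)Nc2cc(C(=O)c3cc(OC)c(OC)c(OC)c3)cc(OC)c2OC)cc1`, which gives 9400 nM, and compound 2 `COc1cccc(/C=C/C(=O)Nc2cc(C(=O)c3cc(OC)c(OC)c(OC)c3)cc(OC)c2OC)c1`, which gives 6700 nM. Compound 3 shows the highest of the three numbers, although a 1.4-fold higher number from compound 1 to compound 3 (0.13 log units; within the scatter) and a 1.9-fold higher number from compound 2 to compound 3 (0.28 log units; within the scatter), so the three compounds cannot be told apart with confidence.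

Compound 4 `COc1cc(C(=O)c2cc(OC)c(OC)c(OC)c2)cc(NC(=O)/C=C/c2ccc(F)cc2)c1OC` has not yet been measured. It differs from compound 3 in one place: 4-fluorophenyl in place of 3-amino-4-methoxyphenyl on a double-bonded chain carbon bound to a double-bonded chain carbon.

Among the measured compounds shown here, two measured steps bear on this change. Moving the methoxy group around the outer ring, a 1.4-fold lower number from compound 1 to compound 2 (0.15 log units; within the scatter), and adding an amino group to that ring, a 1.4-fold higher number from compound 1 to compound 3 (0.13 log units; within the scatter), both left the number essentially where it was. For the measured compounds named here, no measured step introduces a fluorine, so that part of the change has no direct precedent. The steps shown stay within the scatter. Only a small step is expected for compound 4, with no clear direction.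

Compound 4 is therefore expected to give about 8000 nM in this assay, within a range of 3000 nM to 22000 nM, which means an expected change of a 1.6-fold lower number from compound 3 to compound 4 (0.20 log units; within the scatter).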

Compound 4, half-maximal inhibitory concentration: 900 nM
Beside the measured number, compound 4's estimate is 8.9-fold (0.95 log units) above it; measured number outside the range, below it.
By their numbers in this assay, from the lowest: compound 4; then compounds 2, 1 and 3 (each within the scatter of the next).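

Earlier changes on this outer ring, moving the methoxy group or adding an amino group, left the number in this assay within the scatter, but the 4-fluorophenyl group gives a clear drop: a 14-fold lower number from compound 3 to compound 4 (1.15 log units; beyond the scatter) and a 7.4-fold lower number from compound 2 to compound 4 (0.87 log units; beyond the scatter) and a 10-fold lower number from compound 1 to compound 4 (1.02 log units; beyond the scatter). The group on the double-bonded chain carbon can therefore shift this number well beyond the scatter, and the step from compound 1, where fluoro replaces methoxy on an aromatic carbon, shows that a single-group exchange on the ring is enough. No measurement shown here accounts for this drop.

The compounds shown leave open whether the fluorine itself matters or whether removing the methoxy group is enough, and a plain phenyl group or a 4-chlorophenyl group at this place would help separate those two readings. Going by these compounds, it also remains open whether fluoro at another ring carbon, or a second fluorine on the same ring, would keep the lower number.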